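The source may report more compounds than this note shows. Statements on the series, on what has been measured and on what is new or still open speak of the compounds shown alone.

Compound 3 `O=c1c2ccccc2c(-c2ccccc2)nn1CCCCCn1ccnc1` stands at 69% in an assay on isolated protein (Oryctolagus cuniculus) for inhibition of Thromboxane-A synthase (Homo sapiens), tested at 1 uM; on this read-out higher numbers stand for more inhibition at the one concentration tested (going by the name of the read-out) and lower numbers for less inhibition. Compound 2 `O=c1c2ccccc2c(-c2ccccc2)nn1CCCCn1ccnc1` gives 65%, a number within the scatter of it (a number 4 percentage points higher from compound 2 to compound 3 (within the scatter)), while compound 1 `O=c1c2ccccc2c(-c2ccccc2)nn1CCCn1ccnc1` gives 57%, a step beyond the scatter (a number 12 percentage points higher from compound 1 to compound 3 (beyond the scatter)). Compound 4 `O=c1c2ccccc2c(-c2ccccc2)nn1CCCCCCn1ccnc1` carries the change ((1H-imidazol-1-yl)methyl in place of 1H-imidazol-1-yl on a saturated chain carbon, five bonds along the chain from an aromatic nitrogen). Two measured steps are of the same kind and therefore bear on it: a number 8 percentage points higher from compound 1 to compound 2 (within the scatter) and a number 4 percentage points higher from compound 2 to compound 3 (within the scatter), both within the scatter and both pointing upward. On that basis compound 4 is expected to show, in this assay, a step of a number 3 percentage points higher from compound 3 to compound 4 (within the scatter), which is not beyond the scatter, with upward direction if any. Compound 4 is estimated at 72%, within a range from 60% to 82%.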

Compound 4, a percentage reported as inhibition, at one concentration (the size of the read-out at that concentration, not a potency): 79%
Compound 4: middle estimate off by 7 percentage points, on the low side; low and high end bracket the measured number.
By their numbers in this assay, from the lowest: compounds 1, 2, 3 and 4 (each within the scatter of the next, the first and the last beyond it).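

In this assay, (1H-imidazol-1-yl)methyl in place of 1H-imidazol-1-yl, five bonds along the chain from an aromatic nitrogen, gives a number 10 percentage points higher from compound 3 to compound 4 (within the scatter), so this single extension still stays inside the scatter. The larger extensions give a number 14 percentage points higher from compound 2 to compound 4 (beyond the scatter) and a number 22 percentage points higher from compound 1 to compound 4 (beyond the scatter), and both lie beyond it. Across the four compounds, the single extension repeats at a similar size: the same change on two cores in this assay, a number 8 percentage points higher (within the scatter) from compound 1 to compound 2 and a number 10 percentage points higher (within the scatter) from compound 3 to compound 4, 2 percentage points apart, within the scatter of two such steps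

The compounds shown leave open whether a longer chain would continue this course or reverse it. They also leave open how a pyridine in place of the imidazole would read.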